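A few compounds are considered here, and "the series" means these few. Any claim that something is new, unique, unknown or untested is made for them only; others in the source may bear on it.

Measured so far:
compound 1 `CCOC(=O)C[C@H]1[C@@H](O[Si](C)(C)C(C)(C)C)[C@H](n2cnc3c(NC(=O)Nc4ccccc4)ncnc32)O[C@@H]1COC(=O)NC` — 7.77 nM
compound 2 `CNC(=O)NC[C@H]1O[C@@H](n2cnc3c(NC(=O)Nc4ccccc4)ncnc32)[C@H](O[Si](C)(C)C(C)(C)C)[C@@H]1CC(=O)N(C)OC` — 7.77 nM

In a functional assay on SK-MEL-28 cells (Homo sapiens) for antiproliferative activity (a lower number here means a stronger inhibitor of growth, a higher number a weaker inhibitor of growth), compound 1 gives 7.77 nM, and compound 2 gives 7.77 nM. Compound 2 stands level with compound 1 at the digits shown, within the scatter. Compound 3 `CCOC(=O)C[C@H]1[C@@H](O[Si](C)(C)C(C)(C)C)[C@H](n2cnc3c(NC(=O)Nc4ccccc4)ncnc32)O[C@@H]1CNC(=O)NC` is not yet measured. It differs from compound 2 by ethoxy in place of methoxy(methyl)amino on a carbonyl carbon. Among the measured compounds shown here, no step between measured compounds is available to size this change; since the two measured compounds sit level in this assay, no step beyond the scatter is expected in either direction. Compound 3 is estimated at 8 nM, range 4 nM to 16 nM. The expected step is a 1.0-fold higher number from compound 2 to compound 3 (0.01 log units; within the scatter).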

Compound 3, concentration for 50% growth inhibition: 6.85 nM
Compound 3: middle estimate off by 1.2-fold (0.07 log units), on the high side, and the stated range covers the measured number.
By their numbers in this assay, from the lowest: compounds 3, 1 and 2 (each within the scatter of the next).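

In this assay, ethoxy in place of methoxy(methyl)amino on a carbonyl carbon gives a 1.1-fold lower number from compound 2 to compound 3 (0.05 log units; within the scatter), so this position holds either group with no change beyond the scatter. The other single change, (methylcarbamoyl)amino in place of (methylcarbamoyl)oxy on a saturated chain carbon bound to a saturated ring carbon, gives a 1.1-fold lower number from compound 1 to compound 3 (0.05 log units; within the scatter), also with no change beyond the scatter. No measured evidence bears on these results.

Still open, going by these compounds, is whether a carboxylic acid or a longer ester chain at the carbonyl carbon would shift the number beyond the scatter. The same question stands for a simple amine in place of (methylcarbamoyl)amino.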